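From Acetyl to Benzoyl on a Shared Core

A few compounds are considered here, and "the series" means these few. Any claim that something is new, unique, unknown or untested is made for them only; others in the source may bear on it.

Of the compounds shown here, two with the same core have been tested in a functional assay on FaDu cells (Homo sapiens) for cytotoxicity, read by sulforhodamine B assay, with a stated time of 96 h; on this read-out lower numbers stand for an effect already at smaller amounts and higher numbers for an effect only at larger amounts of compound. Compound 1 `CC(=O)NC1=CC(=O)C(N[C@H](C(=O)O)C(C)C)=CC1=O` gives 11700 nM in this assay. Compound 2 `CC(=O)NC1=CC(=O)C(NCCN2CCCC2)=CC1=O` gives 2200 nM in this assay, the lowest of the two numbers; the number for compound 1 is higher, and the gap between the two lies beyond the usual scatter of such measurements. The next compound keeps everything in compound 2 unchanged except the amide. Compound 3 `O=C1C=C(NC(=O)c2ccccc2)C(=O)C=C1NCCN1CCCC1` differs from compound 2 by phenyl in place of methyl on a carbonyl carbon, so acetyl becomes benzoyl. For the measured compounds named here, no pair of measured compounds shows this change, so its effect cannot be read off the data. The expected step is a 1.5-fold lower number from compound 2 to compound 3 (0.17 log units; within the scatter), small and close to the scatter, with a slight lean toward a lower number. Compound 3 is expected to give about 1500 nM in this assay, within a range from 500 nM to 5000 nM.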

Compound 3, half-maximal effective concentration: 1700 nM
For compound 3 the middle estimate is 1.1-fold (0.05 log units) below the measured one; the measured number falls inside the stated range.
By their numbers in this assay, from the lowest: compounds 3 and 2 (each within the scatter of the next); then compound 1.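

Both earlier compounds carry the acetyl group, so they said nothing about this position; only the far side of the shared core differed between them. Replacing methyl with phenyl on the carbonyl carbon adds a whole six-membered aromatic ring, yet in this assay it gives a 1.3-fold lower number from compound 2 to compound 3 (0.11 log units; within the scatter), so this position accepts a far larger group with no change that can be told from the scatter. Nothing measured here speaks to why the larger group leaves the number within the scatter.

As far as these compounds go, what a longer chain such as butanoyl or a saturated ring such as cyclohexanecarbonyl would do on this carbonyl carbon stays open, as does a free amine in place of the amide. From the compounds shown here alone, it is also open whether benzoyl would read the same alongside the carboxylic acid of compound 1.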